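Chain-extended primary amine analogue in the tryptamine series

The compounds below may be only part of what the source reports. "The series", "measured", "known", "first", "only" and "open" are said of these compounds alone.

Measured so far:
- compound 1, `NCCCc1c[nH]c2ccc(F)cc12`: 50 nM in an assay on urine for inhibition of Myeloperoxidase (Homo sapiens); a higher number here means a weaker inhibitor, a lower number a stronger inhibitor
- compound 2, `Fc1ccc2[nH]cc(CCCN3CCCC3)c2c1`: 320 nM in this assay

Compound 2 holds the highest number of the two measured in this assay; its nearest neighbour is compound 1, and the step of a 6.4-fold higher number from compound 1 to compound 2 (0.81 log units; beyond the scatter) separates them. Compound 3, `NCCCCCCc1c[nH]c2ccc(F)cc12`, has not yet been measured. The change from compound 2 to compound 3 is 3-aminopropyl in place of pyrrolidin-1-yl on a saturated chain carbon, three bonds along the chain from an aromatic carbon. Going by the values given here, the only measured step that bears on it is the one from compound 1 to compound 2, which runs in the opposite direction at the same place and was of modest size, beyond the scatter. Among the compounds with values here, compound 3 returns to an open-chain amine like compound 1, so the expected step of a 4.0-fold lower number from compound 2 to compound 3 (0.60 log units; beyond the scatter) is a return toward the number of compound 1, though the longer chain carries no measured precedent here. Compound 3 is therefore estimated at 80 nM, within 25 nM to 250 nM.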

Compound 3, half-maximal inhibitory concentration: 260 nM
Compound 3: middle estimate off by 3.3-fold (0.51 log units), on the low side, outside the stated range (above it).
By their numbers in this assay, from the lowest: compound 1; then compounds 3 and 2 (each within the scatter of the next).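

In this assay, the open-chain primary amine does not by itself restore the number of compound 1: lengthening the chain by the added 3-aminopropyl gives a 5.2-fold higher number from compound 1 to compound 3 (0.72 log units; beyond the scatter), a loss beyond the scatter. Replacing pyrrolidin-1-yl with 3-aminopropyl at this place gives a 1.2-fold lower number from compound 2 to compound 3 (0.09 log units; within the scatter), so these two quite different chain ends cannot be told apart in this assay, and the earlier step alone did not show that either change could give a similar result. Nothing available here accounts for either step.

From the compounds shown here alone, how the number runs across chain lengths between those of compound 1 and compound 3, for example with an aminopentyl chain on the shared core, stays open. Going by these compounds, it is also open whether a dimethylamino group at the end of the shorter chain would fall with compound 1 or with compound 2.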